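Swapping phenyl for furan on a shared core

The source may report more compounds than this note shows. Statements on the series, on what has been measured and on what is new or still open speak of the compounds shown alone.

Compound 1 `c1ccc(-c2cc(-c3cccs3)cc(-c3ccco3)n2)cc1` is a small aromatic molecule with three ring substituents on its core. In a functional assay on SK-OV-3 cells (Female gonad, Homo sapiens) for antiproliferative activity (a higher number here means that more compound is needed for the effect, a lower number that less compound is needed), compound 1 gives 118000 nM. Two close relatives were measured alongside it: compound 2 `c1coc(-c2cc(-c3cccs3)nc(-c3cccs3)c2)c1` gives 118000 nM, and compound 3 `c1csc(-c2cc(-c3cccs3)nc(-c3cccs3)c2)c1` gives 118000 nM. The three values sit at the same level within the usual scatter, so none can be called more or less potent than another.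

The step from compound 2 to compound 3 replaces furan-2-yl with thiophen-2-yl on an aromatic carbon and gave no change at the digits printed from compound 2 to compound 3 (within the scatter); exchanging one small five-membered heteroaromatic ring for another left the read-out where it was.

Compound 4 `c1coc(-c2cc(-c3cccs3)cc(-c3ccco3)n2)c1` is the unmeasured compound. Its change from compound 1 is furan-2-yl in place of phenyl on an aromatic carbon, at the position next to the ring nitrogen. Among the measured compounds shown here, this is a different exchange from the one measured, so the single measured step is only a loose guide. Still, every variation made so far on this core left the number unchanged, and the same is expected here: the estimated step from compound 1 to compound 4 is no change at the digits printed from compound 1 to compound 4 (within the scatter). Compound 4 is therefore expected to give about 118000 nM, most likely between 59000 nM and 236000 nM.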

Compound 4, half-maximal effective concentration: 118000 nM
For compound 4 middle estimate and measured number coincide at the digits printed; the range from low to high includes it.
By their numbers in this assay, from the lowest: compounds 1, 2, 3 and 4 (each within the scatter of the next).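

In this assay, the exchange at this position gives no change at the digits printed from compound 1 to compound 4 (within the scatter), so the result now reaches beyond the earlier step, in which one five-membered aromatic ring replaced another. Here, on an aromatic carbon next to the ring nitrogen, a six-membered aromatic ring of carbon only gives way to a five-membered aromatic ring with 1 hetero atom, and a hydrogen-bond acceptor enters where the phenyl group had none, yet the read-out stays level. No measurement offered here explains why the number stays the same in this exchange.

The compounds shown carry only phenyl, furan-2-yl and thiophen-2-yl groups on the shared core, so they leave open whether a group of another kind at this position, such as an amine, a carboxylic acid or a longer chain, would move the number at all. With all four compounds level, they also leave open which of the three ring positions, if any, has a bearing on the antiproliferative read-out.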